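The compounds below may be only part of what the source reports. "The series", "measured", "known", "first", "only" and "open" are said of these compounds alone.

Of the compounds shown here, two on one shared core have been measured in a functional assay on HepG2 cells (Homo sapiens) for cytotoxicity, read by MTT assay; on this read-out lower numbers stand for stronger inhibition and higher numbers for weaker inhibition. There compound 1 `COc1ccc(/C=C/C(=O)c2ccc(OC)c3c2OC(C)(C)C=C3)cc1OC(=O)C1CC1`, which carries a (cyclopropylcarbonyl)oxy group, gives 220 nM, while compound 2 `COc1ccc(/C=C/C(=O)c2ccc(OC)c3c2OC(C)(C)C=C3)cc1CS(C)(=O)=O` gives 9180 nM, the higher of the two numbers. Compound 3 `COc1ccc(/C=C/C(=O)c2ccc(OC)c3c2OC(C)(C)C=C3)cc1OS(=O)(=O)Cc1ccccc1` differs from compound 2 at one place: (benzylsulfonyl)oxy in place of (methylsulfonyl)methyl on an aromatic carbon. The new (benzylsulfonyl)oxy group stands on an aromatic carbon, ortho to a methoxy group. Among the measured compounds shown here, only one measured step bears on this change: a 42-fold higher number from compound 1 to compound 2 (1.62 log units; beyond the scatter), a large step in which (methylsulfonyl)methyl replaced (cyclopropylcarbonyl)oxy at the same place. For the measured compounds named here, no measured compound carries a benzyl group, so that step offers only a partial guide. The (benzylsulfonyl)oxy group is joined through oxygen as in compound 1, at 220 nM, and it contains a sulfonyl as in compound 2, at 9180 nM, so a number between these two is expected. In this assay the expected change is estimated as a 6.1-fold lower number from compound 2 to compound 3 (0.79 log units; beyond the scatter), a move toward a lower number. For compound 3 the estimated value is 1500 nM, with an expected range from 350 nM to 6500 nM.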

Compound 3, half-maximal inhibitory concentration: > 10000 nM
Compound 3 gave a limit, no number; the forecaster's own chance of this, stated with the estimate: 3%; middle value at least 6.6-fold (0.82 log units) from the limit.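

In this assay compound 3 gives a limit of the assay and no number: the limit of > 10000 nM in this assay, at which 1 of the 3 values shown sits. With the oxygen on the aromatic ring kept, benzylsulfonyl in place of cyclopropylcarbonyl gives an at least 45-fold higher number from compound 1 to compound 3 (1.65 log units; beyond the scatter), so at this position, ortho to a methoxy group, the oxygen link alone does not hold the lower number, and what stands on that oxygen matters as much as the link itself. The other step, an at least 1.0-fold higher number from compound 2 to compound 3 (0.03 log units; that floor lies within the scatter), has a floor within the scatter and fixes no order between the (benzylsulfonyl)oxy and (methylsulfonyl)methyl groups, so the two sulfonyl-bearing groups share the high end of the values shown, whether joined through oxygen or through carbon.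

From the compounds shown here alone, it stays open whether the sulfonyl or the benzyl part separates compound 3 from compound 1, a question that a (methylsulfonyl)oxy group or a benzoyloxy group on the same oxygen would address. Also open, going by these compounds, is whether the lower number of compound 1 depends on its cyclopropyl ring, which a simple acetyl group on that oxygen would test.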